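Replacing 3,4-dimethylphenyl with 4-methoxyphenyl on the shared core

The source may report more compounds than this note shows. Statements on the series, on what has been measured and on what is new or still open speak of the compounds shown alone.

In a functional assay on SK-OV-3 cells (Homo sapiens) for cytotoxicity (on this read-out lower numbers stand for stronger inhibition of growth and higher numbers for weaker inhibition of growth), compound 3 (`CSc1ccc(C2=C(c3ccc(C)c(C)c3)C(=O)N3CCCC3C2)cc1`) gives 300 nM, the second highest of three numbers. Compound 2 (`CSc1ccc(C2=C(c3ccc(F)c(F)c3)C(=O)N3CCCC3C2)cc1`) gives 100 nM and compound 1 (`COc1ccc(C2=C(c3ccc(SC)cc3)CC3CCCN3C2=O)cc1OC(=O)CNC(=O)OC(C)(C)C`) gives 20000 nM. Compound 4 (`COc1ccc(C2=C(c3ccc(SC)cc3)CC3CCCN3C2=O)cc1`) has 4-methoxyphenyl in place of 3,4-dimethylphenyl on a double-bonded ring carbon. Going by the values given here, the one measured step at this place is modest: a 3.0-fold higher number from compound 2 to compound 3 (0.48 log units; beyond the scatter). Compound 1 also has a 4-methoxyphenyl there, with a further ester on that ring, so its value sets no level for compound 4. A small step is expected, no larger than that modest one, and slightly towards a lower number: a 1.5-fold lower number from compound 3 to compound 4 (0.18 log units; within the scatter). Compound 4 is estimated at 200 nM, with an expected range of 50 nM to 800 nM.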

Compound 4, concentration for 50% growth inhibition: 3000 nM
Compound 4: middle estimate off by 15-fold (1.18 log units), on the low side, outside the stated range (above it).
By their numbers in this assay, from the lowest: compound 2; then compound 3; then compound 4; then compound 1.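

In this assay, going by these compounds alone, this position proves more sensitive than the one earlier step showed: 4-methoxyphenyl in place of 3,4-dimethylphenyl gives a 10-fold higher number from compound 3 to compound 4 (1.00 log units; beyond the scatter), and in place of 3,4-difluorophenyl it gives a 30-fold higher number from compound 2 to compound 4 (1.48 log units; beyond the scatter) on the shared core. A hydrogen atom in place of the group of 12 heavy atoms on the aromatic carbon gives a 6.7-fold lower number from compound 1 to compound 4 (0.82 log units; beyond the scatter), so that group is not the only part of the 4-methoxyphenyl series that separates it from compound 2. No measured evidence on hand accounts for these steps.

Still open, on these data alone, is how a single ring substituent behaves here: whether an amine or a carboxylic acid in place of the methoxy group would bring the number back towards that of compound 2.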